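Adding a Second Methoxy Group to a Pyrazoline Series

The source may report more compounds than this note shows. Statements on the series, on what has been measured and on what is new or still open speak of the compounds shown alone.

Of the compounds shown here, three of one series have been tested in a functional assay on MCF7 cells (Homo sapiens) for inhibition, read by MTT assay, with a stated time of 48 h; a higher number here means a weaker inhibitor of growth, a lower number a stronger inhibitor of growth. Compound 1 `Cn1cc(C2CC(c3ccccc3)=NN2C(=O)c2cccnc2)c2ccccc21` gives 7200 nM in this assay. Compound 2 `COc1ccc(C(=O)N2N=C(c3ccccc3)CC2c2cn(C)c3ccccc23)cn1` carries one extra group, (methoxy in place of hydrogen on an aromatic carbon), and in this assay compound 2 gives 4310 nM; the step of a 1.7-fold lower number from compound 1 to compound 2 (0.22 log units; within the scatter) is small. Compound 3 `COc1ccc(C2=NN(C(=O)c3cccnc3)C(c3cn(C)c4ccc(Br)cc34)C2)cc1` belongs to the same family but its core differs from that of compound 1 in more than one place, and the difference between the two cores is not broken down here. In this assay compound 3 gives 1560 nM, the lowest of the three numbers, with gaps to compound 2 and compound 1 that lie beyond the usual scatter.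

Compound 4 `COc1ccc(C2=NN(C(=O)c3cccnc3)C(c3cn(C)c4ccc(Br)cc34)C2)cc1OC` has not yet been measured. It differs from compound 3 by methoxy in place of hydrogen on an aromatic carbon. This is the same kind of change as that from compound 1 to compound 2, but not the same: there the methoxy entered a six-membered aromatic ring with one nitrogen, next to the ring nitrogen and para to a large group, whereas here it enters a ring of carbon only, ortho to a methoxy group and meta to a large group. Since the earlier step of a 1.7-fold lower number from compound 1 to compound 2 (0.22 log units; within the scatter) stayed within the scatter, a similarly modest step is expected here, a 1.4-fold lower number from compound 3 to compound 4 (0.15 log units; within the scatter). For compound 4 the estimate in this assay is 1100 nM, within a range from 400 nM to 3500 nM.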

Compound 4, concentration for 50% growth inhibition: 1170 nM
The estimate for compound 4 lay 1.1-fold (0.03 log units) below the measured number; measured number inside the range.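

In this assay, the change of 4-methoxyphenyl to 3,4-dimethoxyphenyl gives a 1.3-fold lower number from compound 3 to compound 4 (0.12 log units; within the scatter). The same kind of change, hydrogen replaced by methoxy on an aromatic carbon, was made on two different cores and on two different kinds of ring, and the two steps cannot be told apart: the same change on two cores in this assay, a 1.7-fold lower number (0.22 log units; within the scatter) from compound 1 to compound 2 and a 1.3-fold lower number (0.12 log units; within the scatter) from compound 3 to compound 4, 1.3-fold (0.10 log units) apart, within the scatter of two such steps. This shows that within these two pairs the change carries over from one core to the other without any visible difference in its size, but it does not show that methoxy lowers the number on either core, as each step on its own is no larger than repeated measurements of this kind would be expected to vary, and two pairs cannot establish a rule for the whole series.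

The compounds shown leave open whether a different group in place of the new methoxy, such as a hydroxyl, an amine, a carboxylic acid or a longer chain like butoxy, would produce a step beyond the scatter. Also open, from the compounds shown here alone, is whether the methoxy step would look the same on other cores of the family or in other cell lines.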